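Methoxy added to the pendant phenyl of compound 3

The compounds below may be only part of what the source reports. "The series", "measured", "known", "first", "only" and "open" are said of these compounds alone.

Compound 3 `COc1ccc(-c2cc3cc(C4C(C#N)=C(N)OC5=C4C(=O)CC(C)(C)C5)cc(C(C)(C)C)c3oc2=O)cc1` stands second highest of the three numbers in a functional assay on the whole organism (strain Swiss albino) with Mus musculus as the target, in the forced swim test, with a stated time of 5 min, at a dose of 0.5 mg/kg by the intraperitoneal route (on this read-out higher numbers stand for more inhibition at the one dose given (going by the name of the read-out) and lower numbers for less inhibition), with compound 3 giving 27.2%. Nearest stands compound 1 `COc1ccc(-c2cc3cc(C4C(C#N)=C(N)OC5=C4C(=O)CC(C)(C)C5)cc(C)c3oc2=O)cc1OC`, which gives 10.4%; furthest stands compound 2 `COc1ccc(-c2cc3cc(C4C(C#N)=C(N)OC5=C4C(=O)CC(C)(C)C5)cc(C(C)C)c3oc2=O)cc1OC`, which gives 86.6%. Among the compounds with values here, the one step measured so far, a number 76.2 percentage points higher from compound 1 to compound 2 (beyond the scatter), concerns a different position on the shared core. Compound 4 `COc1ccc(-c2cc3cc(C4C(C#N)=C(N)OC5=C4C(=O)CC(C)(C)C5)cc(C(C)(C)C)c3oc2=O)cc1OC` differs from compound 3 by methoxy in place of hydrogen on an aromatic carbon. Within the data shown here, no measured pair shows this change, so neither its direction nor its size can be read from the series. The expected step from compound 3 to compound 4 is a number 2.8 percentage points higher from compound 3 to compound 4 (within the scatter), kept within the scatter but with a wide range. Compound 4 is estimated at 30%, between 5% and 65%.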

Compound 4, a percentage reported as inhibition, in the whole organism at one dose (the size of the read-out at that dose, not a potency): 22.5%
For compound 4 the middle estimate is 7.5 percentage points above the measured one, within the range that was stated.
By their numbers in this assay, from the lowest: compound 1; then compounds 4 and 3 (each within the scatter of the next); then compound 2.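

In this assay the change from 4-methoxyphenyl to 3,4-dimethoxyphenyl with tert-butyl held gives a number 4.7 percentage points lower from compound 3 to compound 4 (within the scatter) so this added methoxy does not separate the two compounds. With 3,4-dimethoxyphenyl held, the other substituted aromatic carbon still matters: methyl added to the isopropyl group gives a number 64.1 percentage points lower from compound 2 to compound 4 (beyond the scatter) and tert-butyl in place of methyl gives a number 12.1 percentage points higher from compound 1 to compound 4 (beyond the scatter) and the first of these steps is the larger. No evidence on the cause of these steps is available.

Going by these compounds, whether this methoxy also makes no difference with isopropyl or methyl at the other position remains open. On these data alone, an amine or a carboxylic acid in place of this methoxy also remains open.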